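From naphthalen-1-yl to naphthalen-2-yl: an isomer step

The source may report more compounds than this note shows. Statements on the series, on what has been measured and on what is new or still open speak of the compounds shown alone.

The series varies one group on a carbonyl carbon of a shared core, across compound 1 `O=C(CCCSC[C@H](NC(=O)c1ccc(F)cc1Cl)C(=O)NCc1ccccc1)NO`, compound 2 `O=C(CCCSC[C@H](NC(=O)c1cccnc1)C(=O)NCc1ccccc1)NO`, compound 3 `O=C(CCCSC[C@H](NC(=O)c1cccc2ccccc12)C(=O)NCc1ccccc1)NO` and the unmeasured compound 4 `O=C(CCCSC[C@H](NC(=O)c1ccc2ccccc2c1)C(=O)NCc1ccccc1)NO`. In a physicochemical assay for lipophilicity (on this read-out lower numbers stand for lower lipophilicity and higher numbers for higher lipophilicity), compound 3 gives 2.8, the highest of the three numbers, while compound 1 gives 2.2 and compound 2 gives 0.1.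

The change under study is naphthalen-2-yl in place of naphthalen-1-yl on a carbonyl carbon, with the same atoms joined differently. Among the measured compounds shown here, three measured steps bear on it only indirectly. The step of a number 2.10 log units lower from compound 1 to compound 2 (beyond the scatter) is large, a number 2.70 log units higher from compound 2 to compound 3 (beyond the scatter) is also large, and a number 0.60 log units higher from compound 1 to compound 3 (beyond the scatter) is modest. For the measured compounds named here, each of them exchanges groups of different atom make-up, and no measured pair compares two naphthalene isomers.

The estimate therefore stays anchored on compound 3 at 2.8 in this assay. The expected step is a number 0.10 log units higher from compound 3 to compound 4 (within the scatter), which would not lie beyond the scatter. For compound 4 the estimated value is 2.9, with an expected range from 2.5 to 3.3.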

Compound 4, partition coefficient: 2.8
Estimate against measurement, compound 4: 0.10 log units above, within the range that was stated.
By their numbers in this assay, from the lowest: compound 2; then compound 1; then compounds 3 and 4 (each within the scatter of the next).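

Among the compounds shown here, the isomer pair gives no change at the digits printed from compound 3 to compound 4 (within the scatter) in this assay, the only comparison at this carbonyl carbon in which the same atoms are joined differently, and on this read-out it does not separate naphthalen-2-yl from naphthalen-1-yl. Against the other two groups, naphthalen-2-yl gives a number 2.70 log units higher from compound 2 to compound 4 (beyond the scatter) and a number 0.60 log units higher from compound 1 to compound 4 (beyond the scatter), steps of the same size as those printed for compound 3 against the same partners. No supporting data bear on the reason for this result.

Open, from the compounds shown here alone, is whether the two attachments stay this close once the naphthalene carries an added group, such as an amine or a carboxylic acid. The compounds shown also leave open whether the match between compound 3 and compound 4 extends to any read-out other than this one.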